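Replacing methyl on the ether oxygen of compound 2

The compounds below may be only part of what the source reports. "The series", "measured", "known", "first", "only" and "open" are said of these compounds alone.

Measured so far in an ADME assay on J774 cells (Mus musculus) for cytotoxicity (on this read-out higher numbers stand for an effect only at larger amounts of compound and lower numbers for an effect already at smaller amounts), are these values.
Compound 1 `COC(=O)c1c[nH]c2ccc(OCc3ccccc3)cc2c1=O` gives 7590 nM
Compound 2 `COC(=O)c1c[nH]c2ccc(OC)cc2c1=O` gives 6180 nM
Compound 3 `COC(=O)c1c[nH]c2ccc(C(C)C)cc2c1=O` gives > 20000 nM (a limit of the assay, not a number)

Among the measured compounds shown here, compound 2 holds one of only two exact numbers in the set, and the other, from compound 1, lies within the scatter of it. The next compound to read is compound 4 `COC(=O)c1c[nH]c2ccc(Oc3ccc(F)cc3)cc2c1=O` which differs from compound 2 by 4-fluorophenyl in place of methyl on an oxygen on an aromatic ring and nothing else.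

For the measured compounds named here, the closest precedent is a 1.2-fold lower number from compound 1 to compound 2 (0.09 log units; within the scatter) where phenyl on a saturated chain carbon bound to that oxygen gives way to hydrogen. The other measured step is an at least 3.2-fold higher number from compound 2 to compound 3 (0.51 log units; beyond the scatter) but there isopropyl replaces methoxy on the aromatic carbon, so the oxygen is lost, whereas compound 4 keeps it. That step therefore bears less on this change. Going by the values given here, no measured compound has an aromatic ring bound straight to that oxygen, and the range is kept wide.

The step expected in this assay is a 1.1-fold higher number from compound 2 to compound 4 (0.05 log units; within the scatter) so no change beyond the scatter is expected. The estimated value for compound 4 is 7000 nM (expected range 2500 nM to 20000 nM).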

Compound 4, half-maximal effective concentration: > 20000 nM
Compound 4 ended at the assay's limit; the forecaster's own chance of this, stated with the estimate: 15%; at least 2.8-fold (0.45 log units) between middle value and limit.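

In this assay compound 4 gives > 20000 nM, which is a limit of the assay and not a number. With the oxygen on the aromatic ring kept, the group on that oxygen can still move the read-out beyond the scatter: 4-fluorophenyl in place of methyl gives an at least 3.2-fold higher number from compound 2 to compound 4 (0.51 log units; beyond the scatter), and 4-fluorophenyl in place of benzyl gives an at least 2.6-fold higher number from compound 1 to compound 4 (0.42 log units; beyond the scatter). Until now only the change that removed the oxygen, in compound 3, had gone beyond the scatter, whereas the swap of benzyl and methyl on the oxygen had stayed within it; the two new steps are lower bounds on size: the limit of > 20000 nM in this assay, at which 2 of the 4 values shown sit.

Compound 4 brings in an aromatic ring directly on the oxygen and a fluorine together, so the compounds shown do not separate the two, and phenyl without the fluorine would be the group to read here. Also open, from the compounds shown here alone, are how an amine, a carboxylic acid or a longer alkyl chain on this oxygen would read, and how compound 3 and compound 4 order against each other, since both rest at the limit.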